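Swapping the Cyanoamidine Group for Methylcarbamoyl

This account rests on a few compounds, and the source may have more. Where it says the series, first, only, none or still open, it means among the compounds named here.

Compound 1 `CN(C)/C(=N\C#N)C1=CC(C)(C)Oc2ccc([N+](=O)[O-])cc21`: > 31600 nM (a limit).
Compound 2 `CN(C)/C(=N\C#N)C1=CC(C)(C)Oc2ccc(C(F)(F)F)cc21`: 12600 nM.
Compound 3 `CN(C)/C(=N\C#N)C1=CC(C)(C)Oc2ccc(Cl)cc21`: > 31600 nM (a limit).

In a functional assay (aorta) with Rattus norvegicus as the target (a higher number here means that more compound is needed for the effect, a lower number that less compound is needed), compound 1 gives only a limit and no number: the limit of > 31600 nM in this assay, at which 2 of the 3 values shown sit. Compound 4 `CNC(=O)C1=CC(C)(C)Oc2ccc([N+](=O)[O-])cc21` keeps the core of compound 1 and differs at one place: a group of 4 heavy atoms (2 carbon, 1 nitrogen, 1 oxygen; no ring) in place of a group of 7 heavy atoms (4 carbon, 3 nitrogen; no ring), on a double-bonded ring carbon. Methylcarbamoyl enters on a double-bonded ring carbon. The readable measured steps, an at least 2.5-fold lower number from compound 1 to compound 2 (0.39 log units; beyond the scatter) and an at least 2.5-fold higher number from compound 2 to compound 3 (0.39 log units; beyond the scatter), change a group on an aromatic carbon instead, so they guide this change only loosely. Compound 2 at 12600 nM shows that the shared core can give a number. A modest drop in the number is therefore expected in this assay, starting from a limit. The estimated change is an at least 2.2-fold lower number from compound 1 to compound 4 (0.35 log units; beyond the scatter). For compound 4 the expected value is 14000 nM, with an estimated range from 2500 nM to 40000 nM.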

Compound 4, half-maximal effective concentration: 10.7 nM
Compound 4: middle estimate off by 1300-fold (3.12 log units), on the high side; measured number below the stated range.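

Methylcarbamoyl in place of the cyanoamidine group gives an at least 2900-fold lower number from compound 1 to compound 4 (3.47 log units; beyond the scatter) in this assay. Among the compounds shown here, the earlier compounds all keep the cyanoamidine group and differ only on an aromatic carbon, so this is the first sign that the double-bonded ring carbon strongly affects how much compound is needed.

Compound 1 gives only a limit, so the full size of this step remains unknown: the limit of > 31600 nM in this assay, at which 2 of the 4 values shown sit.

Also open, as far as these compounds go, is how a carboxylic acid, an amine or a longer chain such as ethylcarbamoyl would read at this ring carbon.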